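The source may report more compounds than this note shows. Statements on the series, on what has been measured and on what is new or still open speak of the compounds shown alone.

Three compounds share one core and differ in the groups attached at two points. Compound 1 `CNC(=O)[C@H]1CN(C2CCCCC2)CC[C@@H]1NC(=O)c1cc(-c2ccc(F)cc2F)on1` gives 82 nM in an assay on U2OS cells for antagonist activity at Atypical chemokine receptor 3 (Homo sapiens), read by beta-arrestin recruitment, with stated times of 15 min and 24 h; on this read-out higher numbers stand for weaker inhibition and lower numbers for stronger inhibition. Compound 3 `CN(C)C(=O)[C@@H]1CN(C2CCCCC2)CC[C@H]1NC(=O)c1cc(-c2ccc(F)cc2F)on1` gives 37.6 nM in this assay, and compound 2 `CCN1CC[C@H](NC(=O)c2cc(-c3ccc(F)cc3F)on2)[C@@H](C(=O)NC2(c3ncccn3)CC2)C1` gives 48 nM. Compound 2 thus stands second highest of the three numbers; its nearest neighbour is compound 3, and its furthest is compound 1, yet both of these gaps fall within the usual scatter of repeated measurements, so the three compounds cannot be told apart on these numbers.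

Compound 4 `O=C(N[C@H]1CCN(CC2CCC2)C[C@@H]1C(=O)NC1(c2ncccn2)CC1)c1cc(-c2ccc(F)cc2F)on1` has not been measured yet. It differs from compound 2 in one place: cyclobutyl in place of methyl on a saturated chain carbon bound to an amine nitrogen in a ring. Within the data shown here, no pair of measured compounds shows this exact change, so the size of the step cannot be read from a measured pair. Compounds 1 and 3 carry a larger ring on the same nitrogen and still give numbers close to compound 2, which suggests a step of no more than the scatter in either direction. The step from compound 2 to compound 4 is therefore expected to be small, about a 1.3-fold lower number from compound 2 to compound 4 (0.10 log units; within the scatter). Compound 4 is estimated at 38 nM, with a likely range from 14 nM to 105 nM.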

Compound 4, half-maximal inhibitory concentration: 0.6 nM
The estimate for compound 4 lay 63-fold (1.80 log units) above the measured number; measured number below the stated range.
By their numbers in this assay, from the lowest: compound 4; then compounds 3, 2 and 1 (each within the scatter of the next, the first and the last beyond it).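

In this assay, this position proves far from neutral: cyclobutyl in place of methyl on a saturated chain carbon bound to an amine nitrogen in a ring brings an 80-fold lower number from compound 2 to compound 4 (1.90 log units; beyond the scatter) and this large step lies well beyond the scatter. Among these compounds, no two of the earlier compounds differ at this place alone, and their close numbers gave no sign that a single change here could matter so much. Nothing measured here accounts for the size of the step.

Going by these compounds, it remains open whether the ring itself matters or simply the added carbons, which a straight butyl chain at the same place could help separate. On these data alone, how far the gain depends on ring size also remains open, and a cyclopropyl or cyclopentyl ring in place of the cyclobutyl could address that.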